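Swapping the Piperidine Sulfonamide for a Urea

The source may hold more compounds than are shown below. What is called first, only, known or untested is meant among the compounds shown, and "the series" means these compounds.

Compound 2 `CCS(=O)(=O)N1CCC(CN(C2Cc3cc(C#N)ccc3N(Cc3cncn3C)C2)S(=O)(=O)c2ccccn2)CC1` stands lowest of the three measured compounds in an ADME assay on Caco-2 cells (Homo sapiens) for permeability, in the apical to basolateral direction (a higher number here means that the compound crosses the layer faster, a lower number that the compound crosses the layer more slowly), where compound 2 gives 0.1 10^-6 cm/s. Its two neighbours carry other groups on the same ring nitrogen: compound 1 `Cn1cncc1CN1CC(N(CC2CCN(C(=O)CC(F)(F)F)CC2)S(=O)(=O)c2ccccn2)Cc2cc(C#N)ccc21` gives 0.5 10^-6 cm/s and compound 3 `CC(=O)N1CCC(CN(C2Cc3cc(C#N)ccc3N(Cc3cncn3C)C2)S(=O)(=O)c2ccccn2)CC1` gives 0.5 10^-6 cm/s. The two steps that run from or to compound 2 both lie beyond the scatter: a 5.0-fold lower number from compound 1 to compound 2 (0.70 log units; beyond the scatter) with ethylsulfonyl in place of (2,2,2-trifluoroethyl)carbonyl, and a 5.0-fold higher number from compound 2 to compound 3 (0.70 log units; beyond the scatter) with acetyl in place of ethylsulfonyl. Between compounds 1 and 3 there is no change at the digits printed from compound 1 to compound 3 (within the scatter).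

Compound 4 `CCNC(=O)N1CCC(CN(C2Cc3cc(C#N)ccc3N(Cc3cncn3C)C2)S(=O)(=O)c2ccccn2)CC1` is not yet measured. It differs from compound 2 in a single place: ethylcarbamoyl in place of ethylsulfonyl on an amine nitrogen in a ring. The two measured steps that bear on this change are the ones in which the ethylsulfonyl group leaves or enters, and each of them moved the number in this assay by the same modest amount, always in the direction away from the ethylsulfonyl compound. On that basis compound 4 is expected to give a higher number than compound 2, with a step of about a 4.0-fold higher number from compound 2 to compound 4 (0.60 log units; beyond the scatter). The estimate for compound 4 in this assay is 0.4 10^-6 cm/s, with a range from 0.1 10^-6 cm/s to 1 10^-6 cm/s.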

Compound 4, apparent permeability: 0.6 10^-6 cm/s
The estimate for compound 4 lay 1.5-fold (0.18 log units) below the measured number, within the range that was stated.
By their numbers in this assay, from the lowest: compound 2; then compounds 1, 3 and 4 (each within the scatter of the next).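

With the ethylcarbamoyl group on the amine nitrogen in the ring, this assay gives a 6.0-fold higher number from compound 2 to compound 4 (0.78 log units; beyond the scatter), so a third group attached through a carbonyl carbon now stands apart from the ethylsulfonyl compound. The two other comparisons, a 1.2-fold higher number from compound 3 to compound 4 (0.08 log units; within the scatter) and a 1.2-fold higher number from compound 1 to compound 4 (0.08 log units; within the scatter), both lie within the scatter, so ethylamino, methyl and 2,2,2-trifluoroethyl on that carbonyl carbon cannot be told apart in this assay. Among these four compounds, the low number therefore belongs to compound 2 alone, and the hydrogen-bond donor that enters with ethylcarbamoyl brings no step beyond the scatter against compound 1 or compound 3, although nothing measured here accounts for the gap between compound 2 and the other three compounds.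

Compound 2 is the only sulfonyl compound shown, so these results cannot say whether its low number would also hold for a methylsulfonyl or a phenylsulfonyl group on this nitrogen. They also leave open how a free amine at this nitrogen, or a carboxylic acid on the chain of the carbonyl group, would read in this assay.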